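Benzoate ester series: chloro to methyl on the aryl ring

This account rests on a few compounds, and the source may have more. Where it says the series, first, only, none or still open, it means among the compounds named here.

Three esters of the shared core have been measured in a functional assay on SK-LU-1 cells (Homo sapiens) for antiproliferative activity, read by sulforhodamine B assay, with a stated time of 48 h, tested at 50 uM; on this read-out higher numbers stand for more inhibition at the one concentration tested (going by the name of the read-out) and lower numbers for less inhibition. Compound 1 `CC1=CC[C@H](C(C)C)c2cc(C)c(OC(=O)c3ccc(Cl)cc3)cc21` gives 17.4%, the lowest of the three numbers shown, though compound 3 `CC1=CC[C@H](C(C)C)c2cc(C)c(OC(=O)c3cccc(C(F)(F)F)c3)cc21` gives 18.3% and lies within the scatter of compound 1. Compound 2 `Cc1cc2c(C(C)C)ccc(C)c2cc1OC(=O)c1ccc(C(F)(F)F)cc1` gives 28.7%, a number beyond the scatter above compound 1, but compound 2 differs from compound 1 in more than one place, so no single change can be read from that pair. Within the data shown here, no two measured compounds differ in only one place, so no step of known size is at hand in this assay.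

Compound 4 `CC1=CC[C@H](C(C)C)c2cc(C)c(OC(=O)c3ccc(C)cc3)cc21` has not yet been measured. It differs from compound 1 as follows: methyl in place of chloro on an aromatic carbon. The exchange of chloro for methyl on the aromatic carbon leaves the count of heavy atoms, donors, acceptors and charge unchanged. Among the measured compounds shown here, with no measured step to lean on, and with compound 1 and compound 3 sitting close together at the low end of the numbers in this assay, no step beyond the scatter is expected in either direction. The expected step from compound 1 to compound 4 in this assay is a number 0.6 percentage points higher from compound 1 to compound 4 (within the scatter). Compound 4 is estimated to give 18% in this assay, with a range from 7% to 30%.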

Compound 4, a percentage reported as inhibition, at one concentration (the size of the read-out at that concentration, not a potency): 85.4%
Compound 4: the middle estimate sits 67.4 percentage points below what was measured; measured number above the stated range.
By their numbers in this assay, from the lowest: compounds 1 and 3 (each within the scatter of the next); then compound 2; then compound 4.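

In this assay, among these compounds, the exchange of 4-chlorophenyl for 4-methylphenyl on the shared core gives the first step that can be read at a single place: a number 68 percentage points higher from compound 1 to compound 4 (beyond the scatter). This position, on an aromatic carbon para to a large group, is therefore not indifferent to its substituent, since exchanging chloro for methyl produces a large step at the one concentration tested, although the counts of heavy atoms, hydrogen-bond donors and hydrogen-bond acceptors and the net charge stay the same. No measurement shown explains the size of this step.

Still open, going by these compounds, is how ethyl, methoxy, an amine or a carboxylic acid at this position would read on the same core, and so whether the step is specific to methyl or would follow the departure of chloro with other groups in its place. The read-out at one concentration also leaves open what potency compound 4 would show across a range of concentrations.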